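Methoxy in Place of Fluoro: Notes Toward Compound 4

The source may report more compounds than this note shows. Statements on the series, on what has been measured and on what is new or still open speak of the compounds shown alone.

Three compounds of the series have been run in a functional assay on PC-3 cells (Homo sapiens) for cytotoxicity, read by WST assay, with a stated time of 48 h; on this read-out lower numbers stand for stronger inhibition and higher numbers for weaker inhibition. Compound 1 `COc1ccc2c(/C=C(\C#N)C(=O)c3c[nH]c4cc(OC)ccc34)c[nH]c2c1` gives 27000 nM in this assay. Compound 3 `COc1ccc2c(C(=O)/C(C#N)=C/c3c[nH]c4cc(F)ccc34)c[nH]c2c1` gives 22500 nM in this assay. Compound 2 `COc1ccc2[nH]cc(/C=C(\C#N)C(=O)c3c[nH]c4cc(F)ccc34)c2c1` reaches only the limit of this assay, > 50000 nM. Compound 4 `COc1ccc2c(C(=O)/C(C#N)=C/c3c[nH]c4ccc(OC)cc34)c[nH]c2c1` has not yet been measured in this assay.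

Compounds 3 and 1 differ in one place: methoxy in place of fluoro on an aromatic carbon. The measured step is a 1.2-fold higher number from compound 3 to compound 1 (0.08 log units; within the scatter). The same change separates compound 2 from compound 4: methoxy in place of fluoro on an aromatic carbon. The surroundings of the place are described in the same words for both pairs, so the change is the same, not merely the same kind. The cores of compound 2 and compound 3 are built from the same atoms joined differently; the difference between the two cores is not broken down here. For compound 2 only the limit is known, and the limit of > 50000 nM in this assay, at which 1 of the 3 values shown sits, marks where it sits.

Because the earlier change gave a 1.2-fold higher number from compound 3 to compound 1 (0.08 log units; within the scatter), the change from compound 2 to compound 4 is expected to be of similar small size. For compound 4 the expected step is a step that the limit leaves unreadable from compound 2 to compound 4. Compound 4 is therefore estimated at 60000 nM, with a range from 25000 nM to 150000 nM, and a fair chance that this assay again returns only a limit.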

Compound 4, half-maximal inhibitory concentration: 37100 nM
Beside the measured number, compound 4's estimate is 1.6-fold (0.21 log units) above it, and the stated range covers the measured number.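

In this assay, methoxy in place of fluoro on an aromatic carbon now has a reading on a second core, an at least 1.3-fold lower number from compound 2 to compound 4 (0.12 log units; that floor lies within the scatter). Set beside the same change on the core of compound 3, this reading gives no ground for claiming that the two cores respond differently: the same change on two cores in this assay, a 1.2-fold higher number (0.08 log units; within the scatter) from compound 3 to compound 1 and an at least 1.3-fold lower number (0.12 log units; that floor lies within the scatter) from compound 2 to compound 4; the limit leaves it open whether they differ. It also does not show that the change carries over unchanged from one core to the other, since compound 2 is known only by a limit of the assay, so the step from it has a floor and no measured size: the limit of > 50000 nM in this assay, at which 1 of the 4 values shown sits.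

The compounds shown carry only fluoro or methoxy at the changed place, which leaves open whether another group there, such as an amine or a carboxylic acid, would shift the number in this assay on either core. Also open, on these data alone, is whether the step on the core of compound 2 would stay within the scatter or go beyond it if compound 2 gave a number instead of a limit.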